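The compounds below may be only part of what the source reports. "The series", "measured", "known", "first", "only" and "open" are said of these compounds alone.

Measured compounds:
Compound 1, `CCCCCc1ccc2[nH]c(-c3ccc(C(F)(F)F)cc3)c(C=O)c2c1`: 67 nM
Compound 2, `CCCCCCc1ccc2[nH]c(-c3ccc(C(F)(F)F)cc3)c(C=O)c2c1`: 22 nM
Compound 3, `CCCCc1ccc2[nH]c(-c3ccc(OC)cc3)c(/C=N\C)c2c1`: 27 nM

In a functional assay on MCF7 cells (Homo sapiens) for antiproliferative activity, with a stated time of 5 days (on this read-out lower numbers stand for stronger inhibition and higher numbers for weaker inhibition), compound 1 gives 67 nM and compound 2 gives 22 nM. The two differ only by methyl in place of hydrogen on a saturated chain carbon, five bonds along the chain from an aromatic carbon, and that change gave a 3.0-fold lower number from compound 1 to compound 2 (0.48 log units; beyond the scatter). Compound 3 is built on a different core; how it differs from compound 1 is not broken down here. In this assay compound 3 gives 27 nM.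

Compound 4, `CCCCCc1ccc2[nH]c(-c3ccc(OC)cc3)c(/C=N\C)c2c1`, has not yet been measured. It differs from compound 3 by methyl in place of hydrogen on a saturated chain carbon, four bonds along the chain from an aromatic carbon. This is the same kind of change as between compound 1 and compound 2, though the methyl enters four bonds along the chain from an aromatic carbon rather than five. A lowering of similar size is expected, because the earlier step was a 3.0-fold lower number from compound 1 to compound 2 (0.48 log units; beyond the scatter), giving an expected step of a 1.8-fold lower number from compound 3 to compound 4 (0.26 log units; within the scatter). Compound 4 is therefore estimated at 15 nM in this assay, within 6 nM to 40 nM.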

Compound 4, half-maximal inhibitory concentration: 21 nM
Estimate against measurement, compound 4: 1.4-fold (0.15 log units) below; low and high end bracket the measured number.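

In this assay the added methyl on the core of compound 3 gave a 1.3-fold lower number from compound 3 to compound 4 (0.11 log units; within the scatter), a step within the scatter, whereas the same change on the core of compound 1 lay beyond it. The two steps cannot be told apart, so the data fit a change that carries over from one core to the other: the same change on two cores in this assay, a 3.0-fold lower number (0.48 log units; beyond the scatter) from compound 1 to compound 2 and a 1.3-fold lower number (0.11 log units; within the scatter) from compound 3 to compound 4, 2.4-fold (0.37 log units) apart, within the scatter of two such steps. This does not show that the change acts alike on both cores, as two pairs are few and the step on the core of compound 3 cannot by itself be told from no change.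

The compounds shown leave open what a longer chain would do on either core. Also open, as far as these compounds go, is what an amine or a carboxylic acid at the end of the chain would do.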